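A few compounds are considered here, and "the series" means these few. Any claim that something is new, unique, unknown or untested is made for them only; others in the source may bear on it.

Series notes. Compound 3 `Cc1nc2c3ccccc3ccc2c2nc3c(ccc4ccccc43)c(-c3cc([N+](=O)[O-])ccc3N)c12` gives 17800 nM in a functional assay on AGS cells (Homo sapiens) for cytotoxicity, read by MTT assay, with a stated time of 48 h; a higher number here means a weaker inhibitor, a lower number a stronger inhibitor; it stands second highest of the three numbers, nearer to compound 1 `Cc1nc2c3ccccc3ccc2c2nc3c(ccc4ccccc43)c(-c3ccccc3Cl)c12` with 52500 nM than to compound 2 `Cc1nc2c3ccccc3ccc2c2nc3c(ccc4ccccc43)c(-c3ccccc3S)c12` with 4070 nM. Compound 4 `Cc1nc2c3ccccc3ccc2c2nc3c(ccc4ccccc43)c(C)c12` alters the substituent on the shared core: methyl in place of 2-amino-5-nitrophenyl on an aromatic carbon. Within the data shown here, the steps bearing on this position are a 2.9-fold lower number from compound 1 to compound 3 (0.47 log units; beyond the scatter) and a 4.4-fold higher number from compound 2 to compound 3 (0.64 log units; beyond the scatter); both exchange one aryl for another, so no measured step removes the ring itself. The largest movement from a change at this position is a 13-fold lower number from compound 1 to compound 2 (1.11 log units; beyond the scatter). With the ring gone the outcome is uncertain; a number above that of compound 3 is expected, by a 1.7-fold higher number from compound 3 to compound 4 (0.23 log units; within the scatter). Compound 4 is estimated at 30000 nM, range 8000 nM to 100000 nM.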

Compound 4, half-maximal inhibitory concentration: > 80000 nM
Compound 4 gave a limit, no number; the forecaster's own chance of this, stated with the estimate: 15%; middle value at least 2.6-fold (0.42 log units) away from the limit.
By their numbers in this assay, from the lowest: compound 2; then compound 3; then compound 1. At a limit, above all of these: compound 4.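

In this assay compound 4 gives a limit and not a number: the limit of > 80000 nM in this assay, at which 1 of the 4 values shown sits. Methyl is the first group here to remove the ring at this position, and the change gives an at least 4.4-fold higher number from compound 3 to compound 4 (0.65 log units; beyond the scatter) and an at least 19-fold higher number from compound 2 to compound 4 (1.29 log units; beyond the scatter), so the ring bearing the amino and nitro groups and the ring bearing sulfanyl both go with lower numbers than methyl. The comparison with the 2-chlorophenyl group is less firm, with an at least 1.5-fold higher number from compound 1 to compound 4 (0.18 log units; that floor lies within the scatter), so that aryl group is not separated from methyl.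

Whether the bare ring or its substituents account for the lower numbers stays open. An unsubstituted phenyl, or an amine or carboxylic acid in place of the aryl group on this carbon, would bear on that question.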